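Chalcone-stilbene series: fluoro for methoxy on the aryl ketone

The source may report more compounds than this note shows. Statements on the series, on what has been measured and on what is new or still open speak of the compounds shown alone.

Three compounds of the shared core have numbers in a functional assay on B16-F10 cells (Mus musculus) for antiproliferative activity, read by MTT assay, with a stated time of 48 h; on this read-out higher numbers stand for weaker inhibition and lower numbers for stronger inhibition. Compound 1 `COc1ccc(/C=C/c2cc(OC)cc(OC)c2/C=C/C(=O)c2ccccc2)cc1` gives 3.7 ug/mL. Compound 2 `COc1ccc(/C=C/c2cc(OC)cc(OC)c2/C=C/C(=O)c2ccc(N)cc2)cc1` gives 2.8 ug/mL, and compound 3 `COc1ccc(/C=C/c2cc(OC)cc(OC)c2/C=C/C(=O)c2ccc(OC)cc2)cc1` gives 5.8 ug/mL. The steps were a 1.3-fold lower number from compound 1 to compound 2 (0.12 log units; within the scatter), a 1.6-fold higher number from compound 1 to compound 3 (0.20 log units; within the scatter) and a 2.1-fold higher number from compound 2 to compound 3 (0.32 log units; beyond the scatter). Compound 3 thus carries the highest of the three numbers, though only the gap to compound 2 lies beyond the scatter.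

Compound 4 `COc1ccc(/C=C/c2cc(OC)cc(OC)c2/C=C/C(=O)c2ccc(F)cc2)cc1` differs from compound 3 in one place: fluoro in place of methoxy on an aromatic carbon. Within the data shown here, no measured step replaces methoxy with fluoro, so the nearest guide is the exchange of hydrogen for methoxy, which gave a 1.6-fold higher number from compound 1 to compound 3 (0.20 log units; within the scatter) and stayed within the scatter. A fluoro group, like hydrogen, brings no hydrogen-bond acceptor to that position, so the number for compound 4 is expected to sit between those of compound 1 and compound 3, with an expected step of a 1.3-fold lower number from compound 3 to compound 4 (0.11 log units; within the scatter) that would not exceed the scatter. The estimate for compound 4 in this assay is 4.5 ug/mL, with a range from 2.5 ug/mL to 8 ug/mL.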

Compound 4, half-maximal inhibitory concentration: 5.3 ug/mL
Beside the measured number, compound 4's estimate is 1.2-fold (0.07 log units) below it; the measured number falls inside the stated range.
By their numbers in this assay, from the lowest: compounds 2, 1, 4 and 3 (each within the scatter of the next, the first and the last beyond it).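

In this assay, methoxy and fluoro on this ring are not told apart at this position: the hydrogen-bond acceptor of methoxy goes, yet the result is (a 1.1-fold lower number from compound 3 to compound 4 (0.04 log units; within the scatter)), within the scatter. Fluoro also stays within the scatter of hydrogen (a 1.4-fold higher number from compound 1 to compound 4 (0.16 log units; within the scatter)) and of amino (a 1.9-fold higher number from compound 2 to compound 4 (0.28 log units; within the scatter)), so the gap between amino and methoxy remains the only pair in this set of four that is separated beyond the scatter, and fluoro does not reproduce it. No measurement on hand accounts for these small steps.

Going by these compounds, whether a carboxylic acid, a dimethylamino group or a longer alkyl chain at this position would move the number beyond the scatter of hydrogen remains open. Also open, on these data alone, is whether the same small steps would appear on any other cell line.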